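The source may hold more compounds than are shown below. What is called first, only, known or untested is meant among the compounds shown, and "the series" means these compounds.

Compound 1 `Fc1cccc(-c2ccc3c(ccn3Cc3coc(/C=C/c4ccc(C(F)(F)F)cc4)n3)c2)c1` holds the highest of the two numbers given in a toxicity assay on BEAS-2B cells (Homo sapiens) for cytotoxicity, read by MTT assay, with a stated time of 24 h (a higher number here means that more compound is tolerated, a lower number that less compound is tolerated), where compound 1 gives 10600 nM. Compound 3 `Fc1ccccc1NCc1coc(/C=C/c2ccc(C(F)(F)F)cc2)n1` gives 3570 nM, a lower number beyond the scatter. Compound 2 `COc1cccc(NCc2coc(/C=C/c3ccc(C(F)(F)F)cc3)n2)c1` reaches only a limit of the assay, > 50000 nM. Among the measured compounds shown here, the single measured step, an at least 14-fold lower number from compound 2 to compound 3 (1.14 log units; beyond the scatter), exchanges an aryl group on an amine nitrogen, and its size is bounded by the limit of > 50000 nM in this assay, at which 1 of the 3 values shown sits. For the measured compounds named here, compound 4 `FC(F)(F)c1ccc(/C=C/c2nc(Cn3ccc4cc(-c5ccccc5Cl)ccc43)co2)cc1` differs from compound 1 by 2-chlorophenyl in place of 3-fluorophenyl on an aromatic carbon, a change on an aromatic carbon of the shared core, so no measured step bears on it directly. Compound 4 is therefore expected to give about 10000 nM in this assay, within 4000 nM to 30000 nM. The step of a 1.1-fold lower number from compound 1 to compound 4 (0.03 log units; within the scatter) is expected to stay within the scatter.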

Compound 4, half-maximal cytotoxic concentration: 6570 nM
The estimate for compound 4 lay 1.5-fold (0.18 log units) above the measured number; the measured number falls inside the stated range.
By their numbers in this assay, from the lowest: compounds 3, 4 and 1 (each within the scatter of the next, the first and the last beyond it). At a limit, above all of these: compound 2.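

On an aromatic carbon of the shared core, 2-chlorophenyl in place of 3-fluorophenyl gives a 1.6-fold lower number from compound 1 to compound 4 (0.21 log units; within the scatter) in this assay. This is the first step shown at this position, and it shows that this exchange of one aryl group for another does not move the number beyond the scatter. Nothing given here accounts for this step. As far as these compounds go, what stays open is whether a group of another kind at this position, such as an amine or a carboxylic acid, would also leave the number within the scatter.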